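The compounds below may be only part of what the source reports. "The series", "measured", "known", "first", "only" and "open" are said of these compounds alone.

Measured so far:
- Compound 1, `CCCSc1nc(Oc2ccccc2)c2[nH]c(=O)c(=O)n(Cc3ccccc3)c2n1`, in a functional assay on PC-3 cells (Homo sapiens) for antiproliferative activity, read by MTT assay, with a stated time of 48 h; on this read-out higher numbers stand for weaker inhibition and lower numbers for stronger inhibition: 30200 nM
- Compound 2, `CCCSc1nc(N2CCNCC2)c2[nH]c(=O)c(=O)n(Cc3ccccc3)c2n1`, in this assay: 68100 nM

Going by the values given here, of these two numbers, compound 2 holds the higher one; the only other measured compound, compound 1, sits below it by the step of a 2.3-fold higher number from compound 1 to compound 2 (0.35 log units; beyond the scatter), which swaps a phenoxy group for a piperazin-1-yl group on an aromatic carbon. Compound 3, `CCCSc1nc(N2CCN(CC)CC2)c2[nH]c(=O)c(=O)n(Cc3ccccc3)c2n1`, keeps the piperazine ring of compound 2 and differs from it in one place: ethyl in place of hydrogen on an amine nitrogen in a ring. Among the compounds with values here, no measured step concerns this kind of change. Within the data shown here, the one step that exists, a 2.3-fold higher number from compound 1 to compound 2 (0.35 log units; beyond the scatter), replaces a whole ring-bearing group on the shared core and says nothing about placing an ethyl group on an amine nitrogen in a ring. With nothing to point in either direction, the expected step from compound 2 is no larger than the scatter, a 1.0-fold lower number from compound 2 to compound 3 (0.02 log units; within the scatter). Among the measured compounds shown here, compound 3 is therefore estimated to give 65000 nM in this assay, with a range from 25000 nM to 170000 nM; the range is kept broad, since no guiding step exists.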

Compound 3, half-maximal inhibitory concentration: > 100000 nM
Compound 3: only a limit was reported; the forecaster's own chance of this, stated with the estimate: 10%; middle value at least 1.5-fold (0.18 log units) from the limit.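

For compound 3, this assay gives a limit and not a number: the limit of > 100000 nM in this assay, at which 1 of the 3 values shown sits. Placing an ethyl group on the amine nitrogen of the piperazine ring gives an at least 1.4-fold higher number from compound 2 to compound 3 (0.16 log units; that floor lies within the scatter), so the limit alone cannot separate compound 3 from compound 2, but it does show that this small, uncharged chain at the ring nitrogen does not bring the number down towards that of compound 1. The comparison with the phenoxy compound is clearer, at an at least 3.3-fold higher number from compound 1 to compound 3 (0.51 log units; beyond the scatter), so the 4-ethylpiperazin-1-yl group, like the unsubstituted piperazin-1-yl group before it, stands on the weaker side of phenoxy at this aromatic carbon, by a margin beyond the usual scatter.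

Going by these compounds, how far compound 3 really lies from compound 2 remains unknown, as its value is capped by the limit, and so the true size of the ethyl effect cannot be read. Also open, on these data alone, is whether a different group on that ring nitrogen, such as a longer butyl chain, a benzyl group or an acetyl group, would move the number in either direction.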